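Three Compounds at the Toxicity Ceiling, a Fourth Expected There

The source may hold more compounds than are shown below. What is called first, only, known or untested is meant among the compounds shown, and "the series" means these compounds.

Three compounds have been tested in a functional assay on MT4 cells (Homo sapiens) for cytotoxicity, read by MTT assay, with a stated time of 5 days; on this read-out higher numbers stand for lower toxicity in this test and lower numbers for higher toxicity in this test:
Compound 1 `Cc1cc(-c2ccc(C#N)c(F)c2)ccc1Oc1ccnc(Nc2ccc(C#N)cc2)n1`: > 296000 nM
Compound 2 `N#Cc1ccc(Nc2nccc(Oc3ccc(-c4ccc(C#N)cc4)c(F)c3)n2)cc1`: > 307000 nM
Compound 3 `Cc1cc(C#N)ccc1-c1ccc(Oc2ccnc(Nc3ccc(C#N)cc3)n2)c(F)c1`: > 296000 nM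

Each of these values is a limit of the assay, not a measured number. Compound 2 sits at the limit of > 307000 nM in this assay, at which 1 of the 3 values shown sits. Compounds 1 and 3 sit at the limit of > 296000 nM in this assay, at which 2 of the 3 values shown sit. So no compound here reached a half-maximal cytotoxic concentration within the tested range, and the three cannot be ranked against each other.

Compound 4 `COc1cc(Oc2ccnc(Nc3ccc(C#N)cc3)n2)ccc1-c1ccc(C#N)cc1` differs from compound 2 by methoxy in place of fluoro on an aromatic carbon. For the measured compounds named here, no measured pair of compounds covers this change, so no step of any size can be read from the data; with every value at a limit, nothing beyond the scatter is expected in this assay. Compound 4 is therefore expected to give about 300000 nM, within 150000 nM to 600000 nM, most likely again as a limit. The expected step of an at least 1.0-fold lower number from compound 2 to compound 4 (0.01 log units; that floor lies within the scatter) lies within the scatter.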

Compound 4, half-maximal cytotoxic concentration: > 298000 nM
Compound 4 gave a limit, no number; the forecaster's own chance of this, stated with the estimate: 80%; the middle value does not contradict the limit.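

Compound 2 and compound 4 both gave limits rather than numbers, so no step can be read between them. The compounds shown leave open at what concentration, if any, each would harm the cells in this assay.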